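Thiocarbonyl substituents: from compound 3 to compound 4

The source may hold more compounds than are shown below. What is called first, only, known or untested is meant among the compounds shown, and "the series" means these compounds.

Measured so far in a functional assay on MCF7 cells (Homo sapiens) for antiproliferative activity, read by MTT assay, with a stated time of 96 h; a higher number here means a weaker inhibitor, a lower number a stronger inhibitor
- compound 1 `O=C1CC2(CCCCC2)Oc2c1ccc1ccccc21` gives 10700 nM
- compound 2 `CSC(=S)N/N=C1\CC2(CCCCC2)Oc2c1ccc1ccccc21` gives 5100 nM
- compound 3 `S=C(N/N=C1\CC2(CCCCC2)Oc2c1ccc1ccccc21)N1CCNCC1` gives 14200 nM

Compound 3 and compound 1 stand within the scatter of each other, so neither is placed ahead, while compound 2 lies clearly apart from compound 3. Among the measured compounds shown here, the only measured step at the thiocarbonyl carbon is a 2.8-fold higher number from compound 2 to compound 3 (0.44 log units; beyond the scatter) and it is modest, with piperazin-1-yl in place of methylsulfanyl.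

Compound 4 `S=C(N/N=C1\CC2(CCCCC2)Oc2c1ccc1ccccc21)NC1CCCCC1` carries cyclohexylamino in place of piperazin-1-yl on a thiocarbonyl carbon, and the counted difference is cyclohexylamino in place of piperazin-1-yl on a thiocarbonyl carbon in full. For the measured compounds named here, no measured compound carries cyclohexylamino, so the direction rests on one comparison only. Leaving piperazin-1-yl is expected to undo roughly what compound 3 showed in a 2.8-fold higher number from compound 2 to compound 3 (0.44 log units; beyond the scatter) and no larger move is foreseen. The estimated change in this assay is a 2.2-fold lower number from compound 3 to compound 4 (0.34 log units; beyond the scatter) and it remains a modest expected step. Compound 4 is estimated at 6500 nM (expected range 2800 nM to 15000 nM).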

Compound 4, half-maximal inhibitory concentration: 15100 nM
Compound 4: middle estimate off by 2.3-fold (0.37 log units), on the low side; measured number above the stated range.
By their numbers in this assay, from the lowest: compound 2; then compounds 1, 3 and 4 (each within the scatter of the next).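

Cyclohexylamino in place of piperazin-1-yl on a thiocarbonyl carbon gives a 1.1-fold higher number from compound 3 to compound 4 (0.03 log units; within the scatter), so a six-membered ring of carbon only and a six-membered ring with 2 hetero atoms are not told apart here. Cyclohexylamino in place of methylsulfanyl gives a 3.0-fold higher number from compound 2 to compound 4 (0.47 log units; beyond the scatter), in the same direction as a 2.8-fold higher number from compound 2 to compound 3 (0.44 log units; beyond the scatter), so the step away from methylsulfanyl now rests on two different ring-bearing groups, not on piperazin-1-yl alone. No measurement available accounts for the separation of compound 2 from compound 3 and compound 4.

Open, from the compounds shown here alone, is whether the lower number of compound 2 extends to other thioether groups on this carbon, such as ethylsulfanyl or benzylsulfanyl. Also open, going by these compounds, is how an open-chain amine such as dimethylamino or a plain amino group compares with the two ring-bearing groups.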